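The source may hold more compounds than are shown below. What is called first, only, known or untested is meant among the compounds shown, and "the series" means these compounds.

Working notes on the series. Going by the values given here, in an assay on brain for inhibition of Monoglyceride lipase (Mus musculus), with a stated time of 30 min (on this read-out higher numbers stand for weaker inhibition and lower numbers for stronger inhibition), compound 1 `O=C(OC(C(F)(F)F)C(F)(F)F)N1CCN(Cc2ccc(C(F)(F)F)cc2N2C[C@H]3CC[C@@H](C2)O3)CC1` gives 14 nM, the second highest of the three numbers measured so far; compound 2 `O=C(OC(C(F)(F)F)C(F)(F)F)N1CCN(Cc2ccc(C(F)(F)F)cc2N2CC[C@H](O)C2)CC1` gives 15 nM and compound 3 `O=C(OC(C(F)(F)F)C(F)(F)F)N1CCN(Cc2ccc(C(F)(F)F)cc2N2CC[C@@H](O)C2)CC1` gives 8 nM. The steps of a 1.1-fold higher number from compound 1 to compound 2 (0.03 log units; within the scatter) and a 1.8-fold lower number from compound 1 to compound 3 (0.24 log units; within the scatter) exchange the group on the aromatic carbon for a smaller one, and the step of a 1.9-fold lower number from compound 2 to compound 3 (0.27 log units; within the scatter) rests on (the fact that compounds 2 and 3 differ only in the configuration as drawn); all three lie within the scatter. Compound 4 `O=C(OC(C(F)(F)F)C(F)(F)F)N1CCN(Cc2ccc(C(F)(F)F)cc2N2CC3COCC3C2)CC1` carries a group of 8 heavy atoms (6 carbon, 1 nitrogen, 1 oxygen; 2 five-membered non-aromatic rings with 1 hetero atom each) in place of a group of 8 heavy atoms (6 carbon, 1 nitrogen, 1 oxygen; one five-membered non-aromatic ring with 1 hetero atom, one six-membered non-aromatic ring with 2 hetero atoms), on an aromatic carbon. Since every measured change at this aromatic carbon stays within the scatter, the expected outcome for no change at the digits printed from compound 1 to compound 4 (within the scatter) is no shift beyond the scatter. Compound 4 is therefore estimated at 14 nM, with a range from 5 nM to 40 nM.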

Compound 4, half-maximal inhibitory concentration: 17 nM
The estimate for compound 4 lay 1.2-fold (0.08 log units) below the measured number; low and high end bracket the measured number.
By their numbers in this assay, from the lowest: compounds 3, 1, 2 and 4 (each within the scatter of the next, the first and the last beyond it).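

Two five-membered non-aromatic rings in place of the five- and six-membered pair change nothing beyond the scatter in this assay (a 1.2-fold higher number from compound 1 to compound 4 (0.08 log units; within the scatter)). Against the smaller group of 6 heavy atoms, the outcome depends on the partner: one step stays within the scatter (a 1.1-fold higher number from compound 2 to compound 4 (0.05 log units; within the scatter)), while the other is the only step in the series beyond it, and only modestly (a 2.1-fold higher number from compound 3 to compound 4 (0.33 log units; beyond the scatter)). That split rests on one stereocentre alone: the fact that compounds 2 and 3 differ only in the configuration as drawn.

As far as these compounds go, whether an open-chain amine or a carboxylic acid on this aromatic carbon would move the number beyond the scatter remains open.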